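Adding a Methyl to the Ring-Bound Nitrogen

A few compounds are considered here, and "the series" means these few. Any claim that something is new, unique, unknown or untested is made for them only; others in the source may bear on it.

The measured compounds:
Compound 1, `CN(c1ccc(Oc2ncnc3sccc23)cc1)c1nccc(N2CCCCC2)n1`, gives 29.3% in a functional assay on MDA-MB-231 cells (Homo sapiens) for inhibition, read by MTT assay, with a stated time of 72 h, tested at 20 uM; on this read-out lower numbers stand for less inhibition and higher numbers for more inhibition at the one concentration tested (going by the name of the read-out).
Compound 2, `CN(c1ccc(Oc2ncnc3sccc23)cc1)c1nccc(N2CCc3ccccc3C2)n1`, gives 24.3% in this assay.
Compound 3, `c1ccc2c(c1)CCN2c1ccnc(Nc2ccc(Oc3ncnc4sccc34)cc2)n1`, gives 9.95% in this assay.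

Compound 3 stands lowest of the three numbers. Compound 2 lies nearest to it, higher and beyond the scatter, and compound 1 furthest, beyond the scatter as well. For the measured compounds named here, the one single-place step measured so far is a number 5 percentage points lower from compound 1 to compound 2 (within the scatter), which concerns the ring attached to the shared core, not the nitrogen.

Compound 4, `CN(c1ccc(Oc2ncnc3sccc23)cc1)c1nccc(N2CCc3ccccc32)n1`, differs from compound 3 by methyl in place of hydrogen on a nitrogen on an aromatic ring. Going by the values given here, no measured step bears directly on this change. Compound 1 and compound 2 both carry the methyl on that nitrogen and both sit well above compound 3, but each also differs from compound 3 in the ring on the other side, so their values only hint that the methyl form can sit higher.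

On that basis the step expected in this assay is estimated as a number 10.1 percentage points higher from compound 3 to compound 4 (beyond the scatter), though with wide uncertainty. Compound 4 is estimated at 20%, ranging from 7% to 33%.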

Compound 4, a percentage reported as inhibition, at one concentration (the size of the read-out at that concentration, not a potency): 17.7%
For compound 4 the middle estimate is 2.3 percentage points above the measured one; the range from low to high includes it.
By their numbers in this assay, from the lowest: compounds 3, 4, 2 and 1 (each within the scatter of the next, the first and the last beyond it).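

In this assay, the step measured directly for methyl in place of hydrogen on a nitrogen on an aromatic ring is a number 7.8 percentage points higher from compound 3 to compound 4 (within the scatter), so at this position the methyl is not shown to change the reading on its own. For the compounds shown here, with the methyl kept in place, compound 4 also allows the ring on the aromatic carbon to be compared: 2,3-dihydro-1H-indol-1-yl in place of 1,2,3,4-tetrahydroisoquinolin-2-yl gives a number 6.6 percentage points lower from compound 2 to compound 4 (within the scatter), whereas 2,3-dihydro-1H-indol-1-yl in place of piperidin-1-yl gives a number 11.6 percentage points lower from compound 1 to compound 4 (beyond the scatter), and only this last step clears the scatter. No measurement at hand offers an explanation for any of these steps.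

The compounds shown leave open how a larger group on this nitrogen, such as ethyl or acetyl, would read. They also leave open whether swapping methyl for hydrogen would give a similar step with piperidin-1-yl or 1,2,3,4-tetrahydroisoquinolin-2-yl on the aromatic carbon, since the methyl and hydrogen forms can be paired directly only with 2,3-dihydro-1H-indol-1-yl.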